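Reversal of the phenol step toward a dimethoxy analogue

The source may report more compounds than this note shows. Statements on the series, on what has been measured and on what is new or still open speak of the compounds shown alone.

Measured so far in a functional assay on HPLF cells (Homo sapiens) for cytotoxicity; on this read-out higher numbers stand for lower toxicity in this test and lower numbers for higher toxicity in this test:
- compound 1 `COc1cc(/C=C2\Cc3ccccc3/C(=C\c3ccc([N+](=O)[O-])cc3)C2=O)cc(OC)c1OC`: > 400000 nM
- compound 2 `COc1ccc(/C=C2\Cc3ccccc3/C(=C\c3ccc([N+](=O)[O-])cc3)C2=O)cc1`: > 400000 nM
- compound 3 `O=C1/C(=C/c2ccc(O)cc2)Cc2ccccc2/C1=C\c1ccc([N+](=O)[O-])cc1`: 75000 nM

The value of compound 1 is a limit of this assay, not a number. The value of compound 2 is likewise a limit. Within the data shown here, compound 3 carries the only number in the set; the two other values sit at the limit of > 400000 nM in this assay, at which 2 of the 3 values shown sit.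

Among the measured compounds shown here, the one measured step is an at least 5.3-fold lower number from compound 2 to compound 3 (0.72 log units; beyond the scatter). It runs from a limit to a number, so its true size is open upward.

Compound 4 `COc1ccc(/C=C2\Cc3ccccc3/C(=C\c3ccc([N+](=O)[O-])cc3)C2=O)cc1OC` is not yet measured. It differs from compound 3 by 3,4-dimethoxyphenyl in place of 4-hydroxyphenyl on a double-bonded chain carbon bound to a double-bonded ring carbon. This undoes the change that separated compound 2 from compound 3 and adds a second methoxy on the same ring.

The step from compound 2 to compound 3 is the only one that bears on the new change, and it ran in the direction of a lower number when the methyl was removed. Putting methyl back, with a further methoxy, is therefore expected to move compound 4 toward the region where compound 1 and compound 2 sit. The step expected is a 5.3-fold higher number from compound 3 to compound 4 (0.73 log units; beyond the scatter). For compound 4 the estimate is 400000 nM, in the range 150000 nM to 800000 nM, with a considerable chance that only a limit is reported.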

Compound 4, half-maximal cytotoxic concentration: > 400000 nM
Compound 4: no number, only a limit; the forecaster's own chance of this, stated with the estimate: 65%; the middle value lies on the limit itself.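

In this assay, the change to 3,4-dimethoxyphenyl gives an at least 5.3-fold higher number from compound 3 to compound 4 (0.72 log units; beyond the scatter), so this place now has a second replacement for 4-hydroxyphenyl that ends without a number, and the earlier single comparison no longer stands alone. Compound 4 gives > 400000 nM, which is a limit of the assay and not a number. The steps linking compound 4 with compound 2 and with compound 1 cannot be read, so no effect of adding or removing a methoxy can be seen in this assay, and the three methoxy-bearing compounds sit together: the limit of > 400000 nM in this assay, at which 3 of the 4 values shown sit.

On these data alone, the true size of the step to compound 4 remains open upward, and how far the three methoxy-bearing compounds differ from one another remains unknown. Also open, as far as these compounds go, is whether the number seen with compound 3 is tied to the hydroxyl itself, or whether an amine or a carboxylic acid in its place on the same ring would also bring the read-out down from the limit.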